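The source may hold more compounds than are shown below. What is called first, only, known or untested is meant among the compounds shown, and "the series" means these compounds.

- compound 1 (`CCCCCC/C=C\CCCCCCCCOC[C@H]1NC[C@H](O)[C@@H]1O`) gives 6000 nM
- compound 2 (`CCCCCCCC/C=C\CCCCCCCCOC[C@H]1NC[C@H](O)[C@@H]1O`) gives 2000 nM
- compound 3 (`O[C@H]1[C@@H](O)CN[C@@H]1COCCCCCCCC/C=C/c1ccc(Oc2ccccc2)cc1`) gives 15000 nM

In a functional assay on SK-BR-3 cells (Homo sapiens) for inhibition, with a stated time of 72 h (on this read-out lower numbers stand for stronger inhibition and higher numbers for weaker inhibition), compound 2 stands lowest of the three at 2000 nM, and its distance from each of the other two lies beyond the scatter. Compound 4 (`CCCCCCCC/C=C\CCCCCCCCNC[C@H]1NC[C@H](O)[C@@H]1O`) departs from compound 2 in one place: ((3,4-dihydroxypyrrolidin-2-yl)methyl)amino in place of (3,4-dihydroxypyrrolidin-2-yl)methoxy on a saturated chain carbon, eight bonds along the chain from a double-bonded chain carbon. Within the data shown here, no measured step covers this exchange. The only one, a 3.0-fold lower number from compound 1 to compound 2 (0.48 log units; beyond the scatter), is modest and concerns the chain rather than this group, so it bears only loosely. The data give no direction, and no step beyond the scatter is expected in this assay. The expected step is a 1.3-fold lower number from compound 2 to compound 4 (0.10 log units; within the scatter). For compound 4 the estimated value is 1600 nM, within an expected range of 500 nM to 5000 nM.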

Compound 4, half-maximal inhibitory concentration: 10000 nM
Compound 4: middle estimate off by 6.3-fold (0.80 log units), on the low side; measured number outside the range, above it.
By their numbers in this assay, from the lowest: compound 2; then compounds 1, 4 and 3 (each within the scatter of the next, the first and the last beyond it).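

In this assay, ((3,4-dihydroxypyrrolidin-2-yl)methyl)amino in place of (3,4-dihydroxypyrrolidin-2-yl)methoxy gives (a 5.0-fold higher number from compound 2 to compound 4 (0.70 log units; beyond the scatter)), a step beyond the scatter. The earlier step changed only the chain, whereas this one shows that the link to the chain also counts, even with the chain unchanged and only one hydrogen-bond donor added. Nothing available accounts for this loss.

From the compounds shown here alone, whether a thioether or an amide link would stay closer to compound 2 or to compound 4 remains open. So does whether the amino link has the same effect on the shorter chain of compound 1.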